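From pyridazin-4-yl to 3-fluoropyridin-4-yl on a shared core

This account rests on a few compounds, and the source may have more. Where it says the series, first, only, none or still open, it means among the compounds named here.

Three amides on a shared core have been measured in a physicochemical assay for solubility, measured as kinetic solubility, with a stated time of 1 h, at pH 7.4; on this read-out lower numbers stand for lower solubility and higher numbers for higher solubility. Compound 1 (`CC(=O)NC1=NN(c2ccc(Cl)c(Cl)c2)CC1`) gives 31000 nM, compound 2 (`O=C(NC1=NN(c2ccc(Cl)c(Cl)c2)CC1)c1ccccn1`) gives 11000 nM and compound 3 (`O=C(NC1=NN(c2ccc(Cl)c(Cl)c2)CC1)c1ccnnc1`) gives 23000 nM. The data show a 1.3-fold lower number from compound 1 to compound 3 (0.13 log units; within the scatter), and they also show a 2.1-fold higher number from compound 2 to compound 3 (0.32 log units; beyond the scatter), so only compound 2 stands apart.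

Compound 4 (`O=C(NC1=NN(c2ccc(Cl)c(Cl)c2)CC1)c1ccncc1F`) has 3-fluoropyridin-4-yl in place of pyridazin-4-yl on a carbonyl carbon. Among the compounds with values here, two measured steps bear on this change, both modest: a 2.8-fold lower number from compound 1 to compound 2 (0.45 log units; beyond the scatter) and a 2.1-fold higher number from compound 2 to compound 3 (0.32 log units; beyond the scatter). Compound 4 carries a pyridinyl group, as compound 2 does, and compound 2 gives 11000 nM, so a small move towards that value is the likeliest outcome. Within the data shown here, no measured compound carries fluorine, which leaves that part of the change untested. The expected change is a 1.6-fold lower number from compound 3 to compound 4 (0.22 log units; within the scatter). For compound 4 the estimated value in this assay is 14000 nM, with an expected range from 7000 nM to 28000 nM.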

Compound 4, solubility: 36000 nM
Compound 4: middle estimate off by 2.6-fold (0.41 log units), on the low side; measured number above the stated range.
By their numbers in this assay, from the lowest: compound 2; then compounds 3, 1 and 4 (each within the scatter of the next).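

In this assay the swap on the carbonyl carbon gives a 1.6-fold higher number from compound 3 to compound 4 (0.19 log units; within the scatter) and a 1.2-fold higher number from compound 1 to compound 4 (0.06 log units; within the scatter) as well, so compound 4 cannot be told apart from either compound 3 or compound 1. Within the data shown here, only a 3.3-fold higher number from compound 2 to compound 4 (0.51 log units; beyond the scatter) lies beyond the scatter, so carrying a pyridinyl group does not tie compound 4 to compound 2, and compound 2 remains the one compound of the four that stands apart. Nothing at hand accounts for this result.

As far as these compounds go, what a plain pyridin-4-yl would give in this place stays open, so the share of the fluorine in the step cannot be separated from that of the ring. Also open, from the compounds shown here alone, is how an amine or a carboxylic acid would read on this carbonyl-bearing position of the shared core.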